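From 2,3-dihydro-1,4-benzodioxin-6-yl to 1-methylethenyl at the limit

A few compounds are considered here, and "the series" means these few. Any claim that something is new, unique, unknown or untested is made for them only; others in the source may bear on it.

Of the compounds shown here, three have been tested so far in a functional assay on SK-BR-3 cells (Homo sapiens) for antiproliferative activity, read by MTT assay, with a stated time of 72 h (a higher number here means a weaker inhibitor, a lower number a stronger inhibitor), and none of them gave a number. Compound 1 (`C/C=C1/[C@H](O[C@@H]2O[C@H](CO)[C@@H](O)[C@H](O)[C@H]2O)OC=C(C(=O)OC)[C@H]1CC(=O)OCCc1ccc2c(c1)OCCO2`) gives > 20000 nM, which is a limit of the assay and not a number. Compound 2 (`C/C=C1/[C@H](O[C@@H]2O[C@H](COC(C)=O)[C@@H](OC(C)=O)[C@H](OC(C)=O)[C@H]2OC(C)=O)OC=C(C(=O)OC)[C@H]1CC(=O)OCCC(C)C`) gives > 15000 nM, also a limit. Compound 3 (`C/C=C1/[C@H](O[C@@H]2O[C@H](COC(C)=O)[C@@H](OC(C)=O)[C@H](OC(C)=O)[C@H]2OC(C)=O)OC=C(C(=O)O)[C@H]1CC(=O)O`) gives > 20000 nM, again a limit. Compound 1 therefore stands at the limit of > 20000 nM in this assay, at which 2 of the 3 values shown sit.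

The next compound to be tested is compound 4 (`C=C(C)CCOC(=O)C[C@@H]1C(C(=O)OC)=CO[C@@H](O[C@@H]2O[C@H](CO)[C@@H](O)[C@H](O)[C@H]2O)/C1=C/C`), which keeps the core of compound 1 and differs from it in one place: 1-methylethenyl in place of 2,3-dihydro-1,4-benzodioxin-6-yl on a saturated chain carbon, two bonds along the chain from an oxygen next to a carbonyl group. Here 1-methylethenyl stands in place of 2,3-dihydro-1,4-benzodioxin-6-yl on a saturated chain carbon, two bonds along the chain from an oxygen next to a carbonyl group.

Among the compounds with values here, no pair of measured compounds shows what such a change does, so the only anchor is compound 1 with its limit of > 20000 nM. The estimated change is a number no higher from compound 1 to compound 4 (the limit leaves the size open), and no step beyond the usual scatter is expected in either direction. The half-maximal inhibitory concentration expected for compound 4 is 20000 nM, within an estimated range from 8000 nM to 40000 nM.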

Compound 4, half-maximal inhibitory concentration: > 15000 nM
Compound 4 ended at the assay's limit; the forecaster's own chance of this, stated with the estimate: 80%; the middle value does not contradict the limit.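

Within the data shown here, compound 1 and compound 4 both end at limits of the assay and not at numbers, and no step between them can be read. The compounds shown leave open how strong any of the four is in this assay, and what 1-methylethenyl in place of 2,3-dihydro-1,4-benzodioxin-6-yl does to the half-maximal inhibitory concentration.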